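The source may hold more compounds than are shown below. What is called first, only, known or untested is meant among the compounds shown, and "the series" means these compounds.

Working notes on the series. Compound 1 `Cc1cccc(C)c1-c1cccc(COc2ccc(CC3SC(=O)NC3=O)s2)c1` gives 82 nM in a functional assay on cells for agonist activity at Free fatty acid receptor 1 (Homo sapiens), read by calcium flux (a higher number here means that more compound is needed for the effect, a lower number that less compound is needed), the lowest of the three numbers at hand. Compound 2 `Cc1cccc(C)c1-c1cccc(OCc2ccc(CCC(=O)O)s2)c1` gives 2420 nM in this assay, and compound 3 `Cc1cccc(C)c1-c1cccc(OCn2cc(CCC(=O)O)nn2)c1` gives 32200 nM; both lie beyond the scatter above compound 1, compound 3 furthest.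

Compound 4 `Cc1cccc(C)c1-c1cccc(COc2ccc(C(CC(=O)O)C3CC3)s2)c1` is not yet measured. It differs from compound 1 in one place: 2-carboxy-1-cyclopropylethyl in place of (2,4-dioxo-1,3-thiazolidin-5-yl)methyl on an aromatic carbon. Compound 2 shows that a carboxylic acid on this kind of core can carry activity, though weaker than compound 1. Going by the values given here, no measured step bears directly on this exchange, so the expected step of a 1.5-fold higher number from compound 1 to compound 4 (0.17 log units; within the scatter) is small, in the direction of a slightly higher number, possibly within the scatter. Compound 4 is therefore estimated at 120 nM, with a range from 30 nM to 500 nM.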

Compound 4, half-maximal effective concentration: 3920 nM
Compound 4: the middle estimate sits 33-fold (1.51 log units) below what was measured; measured number above the stated range.
By their numbers in this assay, from the lowest: compound 1; then compounds 2 and 4 (each within the scatter of the next); then compound 3.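

At this place, on an aromatic carbon next to the ring sulfur, 2-carboxy-1-cyclopropylethyl does not match (2,4-dioxo-1,3-thiazolidin-5-yl)methyl in this assay, giving a 48-fold higher number from compound 1 to compound 4 (1.68 log units; beyond the scatter). Both groups count 8 heavy atoms, so the step arises without a change in that count. Nothing at hand explains the size of this step.

The compounds shown leave open what the cyclopropyl ring contributes to this side chain. They also leave open whether a plain 2-carboxyethyl group or a tetrazole at this place would come closer to compound 1.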